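From 4-bromophenyl to 2-formylphenyl: what to expect

This account rests on a few compounds, and the source may have more. Where it says the series, first, only, none or still open, it means among the compounds named here.

- compound 1 `COc1cc(C(=O)/C=C/c2ccc(O)cc2)cc(OC)c1OC`: 16000 nM
- compound 2 `COc1cc(C(=O)/C=C/c2cc(O)ccc2O)cc(OC)c1OC`: > 100000 nM (a limit of the assay)
- compound 3 `COc1cc(C(=O)/C=C/c2ccc(Br)cc2)cc(OC)c1OC`: 80000 nM

In a functional assay on HepG2 cells (Homo sapiens) for inhibition, read by MTT assay, with a stated time of 48 h (a lower number here means a stronger inhibitor, a higher number a weaker inhibitor), compound 3 gives the higher of the two exact numbers, 80000 nM. The gap between the two is a 5.0-fold higher number from compound 1 to compound 3 (0.70 log units; beyond the scatter). Compound 2 has only a limit, > 100000 nM.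

Compound 4 `COc1cc(C(=O)/C=C/c2ccccc2C=O)cc(OC)c1OC` changes the same group: 2-formylphenyl in place of 4-bromophenyl on a double-bonded chain carbon bound to a double-bonded chain carbon. Two measured changes of this group were modest or larger: a 5.0-fold higher number from compound 1 to compound 3 (0.70 log units; beyond the scatter), and an at least 6.2-fold higher number from compound 1 to compound 2 (0.79 log units; beyond the scatter). Neither involves a formyl group, so they suggest only that a shift of that size is possible, with no firm direction. The expected step is a 1.6-fold lower number from compound 3 to compound 4 (0.20 log units; within the scatter), which would not clearly exceed the scatter. Compound 4 is expected near 50000 nM, with an estimated range of 15000 nM to 150000 nM.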

Compound 4, half-maximal inhibitory concentration: > 100000 nM
Compound 4 ended at the assay's limit; the forecaster's own chance of this, stated with the estimate: 20%; middle value at least 2.0-fold (0.30 log units) from the limit.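

In this assay the 2-formylphenyl group joins the other replacements of 4-hydroxyphenyl at this place in sitting clearly behind compound 1, with an at least 6.2-fold higher number from compound 1 to compound 4 (0.79 log units; beyond the scatter) as the step. Against the 4-bromophenyl group the result separates nothing, as an at least 1.2-fold higher number from compound 3 to compound 4 (0.09 log units; that floor lies within the scatter) still has its floor within the scatter. Compound 4 gives only a limit of the assay, as compound 2 does, and the step between those two cannot be read: the limit of > 100000 nM in this assay, at which 2 of the 4 values shown sit.

From the compounds shown here alone, how far beyond that limit compound 2 and compound 4 lie stays open. Also open, going by these compounds, is whether an amine in place of the hydroxy group of compound 1 would hold its activity.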